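Phenyl for amino on a ring nitrogen: compound 3

This account rests on a few compounds, and the source may have more. Where it says the series, first, only, none or still open, it means among the compounds named here.

compound 1 `Cc1cc(C)n2nc(SCc3nnc(SCc4coc5ccccc5c4=O)n3N)nc2n1`: 3000 nM
compound 2 `Cc1cc(C)n2nc(SCc3cc(=O)c4cc(Cl)ccc4o3)nc2n1`: > 25000 nM

Among the measured compounds shown here, in a functional assay on MDA-MB-435S cells (Homo sapiens) for cytotoxicity, read by MTT assay, with a stated time of 72 h (a higher number here means a weaker inhibitor, a lower number a stronger inhibitor), compound 1 gives 3000 nM, the only number in the set. Compound 2 returns a limit rather than a number, > 25000 nM, which is the limit of > 25000 nM in this assay, at which 1 of the 2 values shown sits. For the measured compounds named here, no two measured compounds differ in a single place, so no measured step is at hand. Compound 3 `Cc1cc(C)n2nc(SCc3nnc(SCc4coc5ccccc5c4=O)n3-c3ccccc3)nc2n1` differs from compound 1 by phenyl in place of amino on an aromatic nitrogen. With nothing measured to lean on, the change from compound 1 to compound 3 is expected to stay within the scatter, no change at the digits printed from compound 1 to compound 3 (within the scatter). Compound 3 is estimated at 3000 nM, between 800 nM and 12000 nM.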

Compound 3, half-maximal inhibitory concentration: 2900 nM
The estimate for compound 3 lay 1.0-fold (0.01 log units) above the measured number, and the stated range covers the measured number.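

The aromatic nitrogen of the five-membered ring now has a single-place step, the only one in the series: this assay records a 1.0-fold lower number from compound 1 to compound 3 (0.01 log units; within the scatter) for this change. Phenyl brings a six-membered aromatic ring of carbon only and removes the hydrogen-bond donor and acceptor counted for amino, yet the number holds within the scatter. Nothing shown gives a cause for this result.

Only amino and phenyl are seen at this position. On these data alone, whether methyl, a longer alkyl chain or a carboxylic acid there would keep the number remains open.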